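A few compounds are considered here, and "the series" means these few. Any claim that something is new, unique, unknown or untested is made for them only; others in the source may bear on it.

Measured so far:
compound 1, `CC(=O)OCCC(=O)O[C@H](CC=C(C)C)C1=CC(=O)c2c(O)ccc(O)c2C1=O`, 15700 nM
compound 2, `CCC(O)CO[C@H](CC=C(C)C)C1=CC(=O)c2c(O)ccc(O)c2C1=O`, 16400 nM
compound 3, `CCC(CO[C@H](CC=C(C)C)C1=CC(=O)c2c(O)ccc(O)c2C1=O)OC(C)=O`, 25400 nM

All three share the same core and differ only in the chain carried on the oxygen of the saturated carbon. In a functional assay on DU-145 cells (Homo sapiens) for cytotoxicity, read by MTT assay (a higher number here means a weaker inhibitor, a lower number a stronger inhibitor), compound 1 stands at the lowest of the three numbers, but the spread is small: a 1.0-fold higher number from compound 1 to compound 2 (0.02 log units; within the scatter) and a 1.6-fold higher number from compound 1 to compound 3 (0.21 log units; within the scatter), and likewise a 1.5-fold higher number from compound 2 to compound 3 (0.19 log units; within the scatter). No ordering among them can be read from this.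

Compound 4, `CC(C)=CC[C@@H](OC(=O)C1CCCOC1)C1=CC(=O)c2c(O)ccc(O)c2C1=O`, is not yet measured. Against compound 1 it shows (oxan-3-yl in place of 2-acetoxyethyl on a carbonyl carbon), so the chain on that oxygen is again the only place of change. Every measured step touching that chain lay within the scatter, so the step from compound 1 to compound 4 in this assay is expected to be of the same kind, with no clear direction. Compound 4 is therefore estimated at 16500 nM, between 8000 nM and 34000 nM, which means an expected 1.1-fold higher number from compound 1 to compound 4 (0.02 log units; within the scatter).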

Compound 4, half-maximal inhibitory concentration: 29700 nM
Compound 4: middle estimate off by 1.8-fold (0.26 log units), on the low side; the measured number falls inside the stated range.
By their numbers in this assay, from the lowest: compounds 1, 2, 3 and 4 (each within the scatter of the next).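

In this assay, oxan-3-yl, with its six-membered non-aromatic ring, replaces the open 2-acetoxyethyl on the carbonyl carbon, and the step still lies within the scatter (a 1.9-fold higher number from compound 1 to compound 4 (0.28 log units; within the scatter)). Within the data shown here, this is the first sign that a ring at this place, not only an open chain, leaves the read-out inside the scatter of compound 1, and the same holds against the two ether-linked chains (a 1.2-fold higher number from compound 3 to compound 4 (0.07 log units; within the scatter); a 1.8-fold higher number from compound 2 to compound 4 (0.26 log units; within the scatter)). No measurement at hand bears on this result.

On these data alone, whether any group at this place can move the number beyond the scatter stays open, for instance an amine, a carboxylic acid or a longer chain on the carbonyl carbon. A cyclohexyl ring on that carbon would also be needed to show whether the ring oxygen of oxan-3-yl matters at all.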